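A few compounds are considered here, and "the series" means these few. Any claim that something is new, unique, unknown or untested is made for them only; others in the source may bear on it.

Measured compounds:

Compound 1, `CC1=NN(C(=O)CN2CCN(C(=O)OC(C)(C)C)CC2)C(c2ccccc2O)C1`, in a functional assay on MGC-803 cells (Homo sapiens) for cytotoxicity, read by MTT assay, with a stated time of 48 h (a lower number here means a stronger inhibitor, a higher number a weaker inhibitor), gives 17600 nM.
Compound 2, `CC1=NN(C(=O)CN2CCN(C)CC2)C(c2ccccc2O)C1`, in this assay gives 7850 nM.
Compound 3, `CC(C)(C)OC(=O)N1CCN(CC(=O)N2N=C(c3cc4ccccc4oc3=O)CC2c2ccccc2)CC1`, in this assay gives "not active" (no number reported), with no number behind that report.

The series turns on two cores. Compound 1 and compound 2 share one core; compound 3 carries a different one, and the difference between the two cores is not broken down here. Going by the values given here, on the first core the single change methyl in place of tert-butoxycarbonyl on an amine nitrogen in a ring produced a 2.2-fold lower number from compound 1 to compound 2 (0.35 log units; beyond the scatter), a step beyond the scatter but modest in size.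

Compound 4, `CN1CCN(CC(=O)N2N=C(c3cc4ccccc4oc3=O)CC2c2ccccc2)CC1`, is not yet measured. It is made from compound 3 by methyl in place of tert-butoxycarbonyl on an amine nitrogen in a ring, and since the place lines of the two changes agree word for word this is the same change, applied to the second core. Among the compounds with values here, the only guide is that one earlier step. Within the data shown here, compound 3 gave no number, so the step from compound 3 to compound 4 cannot be anchored to a measured starting point; the expectation is only that the change, if it behaves as it did from compound 1 to compound 2, would move compound 4 into a range where a number might be read rather than leave it unmeasurable. Compound 4 is therefore expected to fall around 60000 nM in this assay, with a wide range from 20000 nM to 200000 nM, and a real chance that it too is reported only as not active.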

Compound 4, half-maximal inhibitory concentration: 46100 nM
Compound 4: the middle estimate sits 1.3-fold (0.11 log units) above what was measured; low and high end bracket the measured number.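

No step can be read from compound 3 to compound 4: in this assay compound 3 gives "not active" (no number reported) and so offers no starting number, while compound 4 gives 46100 nM as a number on its own. The compounds shown leave open whether a change like a 2.2-fold lower number from compound 1 to compound 2 (0.35 log units; beyond the scatter) holds on the core of compound 3. No evidence bears on this result.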